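The source may report more compounds than this note shows. Statements on the series, on what has been measured and on what is new or still open speak of the compounds shown alone.

In a functional assay on Jurkat cells (Homo sapiens) for cytotoxicity, read by luminescence and CellTiter-Glo, with a stated time of 3 days (a lower number here means a stronger inhibitor, a higher number a weaker inhibitor), compound 3 (`N#Cc1ccc(NC(=O)c2ccc3cccnc3c2O)cc1`) gives 180 nM as its value. Compound 1 (`Cc1cc(C#N)ccc1NC(=O)c1ccc2cccnc2c1O`) stands at 270 nM and lies within the scatter of compound 3, while compound 2 (`O=C(Nc1ccc(Cl)cc1Cl)c1ccc2cccnc2c1O`) at 430 nM has a higher number, beyond that scatter.

The next compound is compound 4 (`O=C(Nc1ccc(Cl)cc1)c1ccc2cccnc2c1O`). The change from compound 3 is chloro in place of cyano on an aromatic carbon and amounts to chloro in place of cyano on an aromatic carbon, para to a large group.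

Among the measured compounds shown here, the one measured step of a 1.5-fold lower number from compound 1 to compound 3 (0.18 log units; within the scatter) is a different change, hydrogen in place of methyl, and it leaves the cyano untouched, so it bears only weakly on this swap. For the measured compounds named here, compound 2 at 430 nM is the only measured compound carrying chloro, but no measured single-place step joins it to compound 3. Going by the values given here, the data therefore hold no direct precedent for the swap, and only a modest shift toward the number of compound 2 is expected.

The expected change is a 1.6-fold higher number from compound 3 to compound 4 (0.19 log units; within the scatter) as an estimated step, with the direction toward a higher number in this assay being tentative. In that assay the estimate for compound 4 is 280 nM with an expected range from 130 nM to 600 nM as the likely span.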

Compound 4, half-maximal inhibitory concentration: 510 nM
For compound 4 the middle estimate is 1.8-fold (0.26 log units) below the measured one; measured number inside the range.
By their numbers in this assay, from the lowest: compounds 3, 1, 2 and 4 (each within the scatter of the next, the first and the last beyond it).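

In this assay, the swap of chloro for cyano, para to a large group, now has a direct reading: a 2.8-fold higher number from compound 3 to compound 4 (0.45 log units; beyond the scatter). For this pair the cyano compound therefore holds the lower number, and the gap is larger than the step for hydrogen in place of methyl, a 1.5-fold lower number from compound 1 to compound 3 (0.18 log units; within the scatter), on the same side of the molecule. The other new step, a 1.2-fold higher number from compound 2 to compound 4 (0.07 log units; within the scatter), shows that the second chloro of compound 2 has no readable effect once chloro occupies the para place, so among these pairs only the group at that place gives a step beyond the scatter, and nothing at hand gives a reason for the gap between cyano and chloro.

Cyano and chloro are the only groups shown at this place, so it remains open how an amine, a carboxylic acid or a methoxy group there would read in this assay. As far as these compounds go, the core carrying the hydroxyl group is the same in all four compounds, so it is also open whether the cyano-to-chloro step keeps its size with a methyl or a fluoro on that core.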